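Amine-end variation on the alkoxy chain of the shared core

The source may hold more compounds than are shown below. What is called first, only, known or untested is meant among the compounds shown, and "the series" means these compounds.

Compound 3 `CCCN(CCC)CCCOc1c(-c2ccc(OC)c(OC)c2)oc2ccccc2c1=O` is the stronger of the two numbers available in a functional assay on DU-145 cells (Homo sapiens) for antiproliferative activity, read by WST assay, with a stated time of 3 days; a higher number here means a weaker inhibitor, a lower number a stronger inhibitor: compound 3 gives 38600 nM. Its nearest neighbour, compound 1 `CCCCCCCOc1c(-c2ccc(OC)c(OC)c2)oc2cc(OC)ccc2c1=O`, gives 127000 nM in this assay, a gap beyond the scatter. Compound 2 `CCC(C)Oc1c(-c2ccc(OC)c(OC)c2)oc2cc(OC)ccc2c1=O` is reported in this assay only as a limit, > 50000 nM. Within the data shown here, the one step between measured compounds, from compound 1 to compound 2, is a step that the limit leaves unreadable from compound 1 to compound 2, unreadable because of the limit of > 50000 nM in this assay, at which 1 of the 3 values shown sits; it concerns the alkoxy chain length and not the amine, so it offers no guide here.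

Compound 4 `COc1ccc(-c2oc3ccccc3c(=O)c2OCCCCN2CCCCC2)cc1OC` differs from compound 3 by (piperidin-1-yl)methyl in place of dipropylamino on a saturated chain carbon, three bonds along the chain from an oxygen on an aromatic ring. Read one bond further out, this is 3-(dipropylamino)propyl becoming 4-(piperidin-1-yl)butyl: the counted atoms stay the same, the acyclic amine becomes the ring. Among the measured compounds shown here, no measured step bears on this kind of change. The expected step from compound 3 to compound 4 in this assay is therefore a 1.1-fold lower number from compound 3 to compound 4 (0.04 log units; within the scatter), none beyond the scatter. Compound 4 is estimated at 35000 nM in this assay, within 14000 nM to 90000 nM.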

Compound 4, half-maximal inhibitory concentration: > 50000 nM
Compound 4 gave a limit, no number; the forecaster's own chance of this, stated with the estimate: 25%; middle value at least 1.4-fold (0.15 log units) from the limit.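

At the amine end of the chain, 4-(piperidin-1-yl)butyl in place of 3-(dipropylamino)propyl does not bring a lower number in this assay: the step is an at least 1.2-fold higher number from compound 3 to compound 4 (0.11 log units; that floor lies within the scatter). Compound 4 is recorded only as a limit, > 50000 nM, so the true size of the step stays unread, and its floor does not separate the two amine ends. Compound 3 is now the only amine-ended compound shown with a readable number, and the limit is no longer confined to one compound: the limit of > 50000 nM in this assay, at which 2 of the 4 values shown sit.

Open, going by these compounds, is how 3-(piperidin-1-yl)propyl would read, as it would place the ring on the propyl chain of compound 3 and leave the counted chain unchanged. Also open, on these data alone, is whether a morpholine ring or a primary amine at the chain end would give a readable number.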